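A few compounds are considered here, and "the series" means these few. Any claim that something is new, unique, unknown or untested is made for them only; others in the source may bear on it.

Values in a functional assay on MGC-803 cells (Homo sapiens) for antiproliferative activity, read by CCK-8 assay, with a stated time of 72 h (a higher number here means a weaker inhibitor, a lower number a stronger inhibitor), for the measured compounds:

compound 1 `O=C(Nc1ccc(-c2cnc3cc(C4=CCN(C5COC5)CC4)ccn23)cc1)c1ccc([N+](=O)[O-])o1` gives 1100 nM
compound 2 `CN1CCCN(c2ccn3c(-c4ccc(NC(=O)c5ccc([N+](=O)[O-])o5)cc4)cnc3c2)CC1` gives 3580 nM

For the measured compounds named here, compound 2 holds the higher of the two numbers in this assay; the only measured step, a 3.3-fold higher number from compound 1 to compound 2 (0.51 log units; beyond the scatter), is modest but beyond the scatter, and it shows that exchanging one group for another at this position of the shared core moves the read-out by a limited amount.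

Compound 3 `O=C(Nc1ccc(-c2cnc3ccccn23)cc1)c1ccc([N+](=O)[O-])o1` is the unmeasured member. Its change from compound 2 is hydrogen in place of 4-methyl-1,4-diazepan-1-yl on an aromatic carbon. Going by the values given here, no measured step removes a substituent at this position outright, so the bearing of the one known step is indirect: it fixes only the scale of variation seen when the group here is changed. On that basis a step of about the same size as the measured one, in either direction, is expected for a 1.2-fold lower number from compound 2 to compound 3 (0.08 log units; within the scatter), and the estimate is kept wide.

The expected value for compound 3 in this assay is 3000 nM, with a range from 800 nM to 12000 nM.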

Compound 3, half-maximal inhibitory concentration: 590 nM
Compound 3: middle estimate off by 5.1-fold (0.71 log units), on the high side; the measured number lies below the stated range.
By their numbers in this assay, from the lowest: compounds 3 and 1 (each within the scatter of the next); then compound 2.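

In this assay, for the compounds shown here, hydrogen at this place, opposite the ring nitrogen, gives the first reading of the shared core without a substituent there, and the removal of 4-methyl-1,4-diazepan-1-yl is a 6.1-fold lower number from compound 2 to compound 3 (0.78 log units; beyond the scatter) and so a real difference in this pair. The group of compound 1 does not separate from hydrogen, with a 1.9-fold lower number from compound 1 to compound 3 (0.27 log units; within the scatter) as the printed step, so among these compounds neither substituent gives a lower number than hydrogen beyond the scatter, and only 4-methyl-1,4-diazepan-1-yl stands apart from it. Nothing measured alongside these numbers accounts for the difference between the two substituents.

From the compounds shown here alone, whether a smaller group at this place, such as methoxy or a primary amine, or an open chain such as 2-(dimethylamino)ethoxy, would read with hydrogen or with 4-methyl-1,4-diazepan-1-yl remains open. Going by these compounds, all three compounds also carry the same nitro group, so the effect on the read-out of a nitrile or a carboxylic acid in its place is unknown, and so is whether the order at this position would hold with either of them.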